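The source may hold more compounds than are shown below. What is called first, only, known or untested is meant among the compounds shown, and "the series" means these compounds.

Measured compounds:
- compound 1, `S=c1[nH]nc(-c2ccc3c(c2)OCCO3)o1`, gives 10600 nM in a functional assay, with a stated time of 6 min; on this read-out higher numbers stand for weaker inhibition and lower numbers for stronger inhibition
- compound 2, `S=c1oc(-c2ccc3c(c2)OCCO3)nn1CNc1ccc(Cl)cc1`, gives 7270 nM in this assay
- compound 3, `O=[N+]([O-])c1ccc(NCn2nc(-c3ccc4c(c3)OCCO4)oc2=S)c(Cl)c1`, gives 8660 nM in this assay

The three compounds share one core and differ only in what sits on it. On the numbers shown, compound 2 carries the smallest value of the three in this assay, yet compound 3 and compound 1 both lie within the usual scatter of it, so nothing separates the three with confidence. For the measured compounds named here, no single-change step between measured compounds is available, and so no measured step can guide the next one.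

The next compound, compound 4, `COc1ccccc1NCn1nc(-c2ccc3c(c2)OCCO3)oc1=S`, has not yet been measured in this assay. It differs from compound 2 in one place: 2-methoxyphenyl in place of 4-chlorophenyl on an amine nitrogen. Since the three measured compounds give values that cannot be told apart, there is no basis for expecting a change beyond the scatter in either direction. The step of a 1.1-fold higher number from compound 2 to compound 4 (0.04 log units; within the scatter) is therefore expected to stay within the scatter. Compound 4 is expected to give about 8000 nM in this assay, with a range from 3000 nM to 22000 nM.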

Compound 4, half-maximal inhibitory concentration: 6300 nM
For compound 4 the middle estimate is 1.3-fold (0.10 log units) above the measured one; the range from low to high includes it.
By their numbers in this assay, from the lowest: compounds 4, 2, 3 and 1 (each within the scatter of the next).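

In this assay, for the compounds shown here, the exchange of 4-chlorophenyl for 2-methoxyphenyl on the amine nitrogen gives the first single-change step, a 1.2-fold lower number from compound 2 to compound 4 (0.06 log units; within the scatter), and that step stays within the scatter. This shows that, for this one pair, the aryl group on this nitrogen can be exchanged, even though the entering group brings a hydrogen-bond acceptor that the leaving group lacks, without a change that can be told from the scatter. Nothing available here explains this result.

The compounds shown leave open whether any group at this place can move the number beyond the scatter, since only two substituted phenyl groups can be compared directly. A plain alkyl chain in place of the phenyl ring, or a carboxylic acid on that ring, remains an open case.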